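Methoxy removal on the benzylamine-substituted core

This account rests on a few compounds, and the source may have more. Where it says the series, first, only, none or still open, it means among the compounds named here.

Measured so far:
compound 1 `[SeH]c1nc(NCc2ccccc2)c2cccnc2n1` in a functional assay on MCF7 cells (Homo sapiens) for cytotoxicity, read by MTT assay, with a stated time of 72 h (a higher number here means a weaker inhibitor of growth, a lower number a stronger inhibitor of growth), gives > 100000 nM, a limit of the assay.
compound 2 `COc1ccc(CNc2nc(SC)nc3ncccc23)cc1` in this assay gives > 100000 nM, also a limit and not a number.

Compound 2 therefore stands at the limit of > 100000 nM in this assay, at which 2 of the 2 values shown sit. Within the data shown here, no step between measured compounds is available. Compound 3 `CSc1nc(NCc2ccccc2)c2cccnc2n1` differs from compound 2 by hydrogen in place of methoxy on an aromatic carbon. Because compound 2 rests at the limit of > 100000 nM in this assay, at which 2 of the 2 values shown sit, no step beyond the scatter is expected here. The expected step is a step that the limit leaves unreadable from compound 2 to compound 3 in this assay. Compound 3 is estimated at 150000 nM (range 30000 nM to 600000 nM), most likely reported again as a limit.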

Compound 3, concentration for total growth inhibition: > 100000 nM
Compound 3 gave a limit, no number; the forecaster's own chance of this, stated with the estimate: 80%; the middle value is on the limit's open side.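

No step can be read among compound 1, compound 2 and compound 3, because each gives only a limit: the limit of > 100000 nM in this assay, at which 3 of the 3 values shown sit.

The compounds shown leave open whether replacing methoxy with hydrogen, or selenium with the group of 2 heavy atoms, changes growth inhibition at all.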